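The compounds below may be only part of what the source reports. "The series", "measured", "known", "first", "only" and "open" are said of these compounds alone.

Notes on a small cytotoxicity series. Compound 1 `CCn1cc(-c2nc3ccccc3o2)c(=O)c2cc(F)c(N3CCN(C)CC3)cc21` and compound 2 `CCn1cc(-c2nc3ccccc3s2)c(=O)c2cc(F)c(N3CCNCC3)cc21` share a core. In a functional assay on KB cells (Homo sapiens) for cytotoxicity, read by MTT assay, with a stated time of 48 h (a higher number here means a weaker inhibitor, a lower number a stronger inhibitor), compound 1 gives 87400 nM. In this assay, going by the values given here, compound 2 gives 28700 nM, the lowest of the two numbers so far. These two compounds differ in more than one place, so only their two values are set side by side, and compound 1 stands at a higher number, beyond the scatter. Compound 3 `CCn1cc(-c2nc3ccccc3s2)c(=O)c2cc(F)c(N3CCN(C)CC3)cc21` has not been measured in this assay. It differs from compound 2 in one place: methyl in place of hydrogen on an amine nitrogen in a ring. Among the compounds with values here, no step between measured compounds isolates this change, and compound 1 carries the methyl only together with a second difference. The expected step from this change is small, likely none beyond the scatter, with a slight lean toward a weaker inhibitor, as a 1.4-fold higher number from compound 2 to compound 3 (0.14 log units; within the scatter). Compound 3 is estimated at 40000 nM, within 12000 nM to 120000 nM.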

Compound 3, half-maximal inhibitory concentration: 19000 nM
Beside the measured number, compound 3's estimate is 2.1-fold (0.32 log units) above it; measured number inside the range.
By their numbers in this assay, from the lowest: compounds 3 and 2 (each within the scatter of the next); then compound 1.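

Methyl in place of hydrogen on an amine nitrogen in a ring gives a 1.5-fold lower number from compound 2 to compound 3 (0.18 log units; within the scatter) in this assay, so on this pair the position takes a methyl with no shift that can be told from the scatter. With 4-methylpiperazin-1-yl common to both compounds, 1,3-benzothiazol-2-yl in place of 1,3-benzoxazol-2-yl on an aromatic carbon can now be read on its own, as a 4.6-fold lower number from compound 1 to compound 3 (0.66 log units; beyond the scatter), which is a modest step beyond the scatter. Nothing measured here accounts for either step.

On these data alone, each step rests on a single pair, so it remains open whether either would hold with the other group changed. Also open, as far as these compounds go, is how this amine nitrogen would respond to a longer chain such as propyl, or to an acetyl group.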